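A few compounds are considered here, and "the series" means these few. Any claim that something is new, unique, unknown or untested is made for them only; others in the source may bear on it.

Measured in a functional assay on K562 cells (Homo sapiens) for cytotoxicity, read by trypan blue exclusion, with a stated time of 96 h; a higher number here means a weaker inhibitor, a lower number a stronger inhibitor:
- compound 1 `COc1cc(OC)c(/C=C/S(=O)(=O)Nc2cc(N)c(OC)c(N)c2)c(OC)c1`: 7500 nM
- compound 2 `COc1ccc(NS(=O)(=O)/C=C/c2c(F)c(F)c(F)c(F)c2F)cc1N`: 75000 nM
- compound 3 `COc1cc(OC)c(/C=C/S(=O)(=O)Nc2ccc(OC)c(OP(=O)(O)O)c2)c(OC)c1`: 7.5 nM

Compound 3 gives the lowest of the three numbers and stands apart from both others by far more than the scatter. Compound 1 lies closer to it than compound 2 does, but the gap is still wide.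

Compound 4 `COC(=O)C(Nc1cc(NS(=O)(=O)/C=C/c2c(OC)cc(OC)cc2OC)ccc1OC)c1ccccc1` keeps the shared core of compound 3 and changes one site: a group of 12 heavy atoms (9 carbon, 1 nitrogen, 2 oxygen; one six-membered aromatic ring of carbon only) in place of a group of 5 heavy atoms (4 oxygen, 1 phosphorus; no ring), on an aromatic carbon. The new group sits ortho to a methoxy group and meta to a large group.

Going by the values given here, no two measured compounds differ in one place, so the data give no direct measure of what a single change does here. Among the compounds with values here, compound 3 is the only measured compound carrying the group that leaves, and its number may not carry over once that group is gone. A move towards a higher number, beyond the scatter, is therefore expected. The series offers a rough upper reference in compound 1 at 7500 nM, and compound 4 is expected to fall short of that number.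

The estimated change is a 20-fold higher number from compound 3 to compound 4 (1.30 log units; beyond the scatter). For compound 4 the expected value is 150 nM, with an estimated range of 12 nM to 2500 nM.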

Compound 4, half-maximal inhibitory concentration: 2500 nM
Estimate against measurement, compound 4: 17-fold (1.22 log units) below; low and high end bracket the measured number.
By their numbers in this assay, from the lowest: compound 3; then compound 4; then compound 1; then compound 2.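

In this assay, the site on the aromatic carbon, ortho to a methoxy group, now has its first one-place comparison: a 330-fold higher number from compound 3 to compound 4 (2.52 log units; beyond the scatter), a large step. The site is therefore not indifferent to what it carries, and the low number of compound 3 does not survive the exchange of its group of 5 heavy atoms (4 oxygen, 1 phosphorus) for a group of 12 heavy atoms with one six-membered aromatic ring of carbon only. No measurement at hand accounts for the size of this step.

Going by these compounds, a single step cannot separate the loss of the group that leaves from the gain of the group that enters, so the share of each in the change stays open. Whether a hydroxyl group or a carboxylic acid at this place would give a number nearer to that of compound 3 or to that of compound 4 is also unsettled, and compound 1 and compound 2 differ from these two in more than one place and cannot decide it.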